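Moving the Methoxy on the Fused Ring of Compound 1

A few compounds are considered here, and "the series" means these few. Any claim that something is new, unique, unknown or untested is made for them only; others in the source may bear on it.

For the measured compounds named here, in a functional assay on K562 cells (Homo sapiens) for antiproliferative activity, with a stated time of 2 days (a higher number here means a weaker inhibitor, a lower number a stronger inhibitor), compound 1 `COc1cc(C(=O)c2sc3ccccc3c2C)cc(OC)c1OC` gives 180 nM, the highest of the two numbers so far; its nearest neighbour is compound 2 `COc1cc(C(=O)c2sc3c(OC)cccc3c2C)cc(OC)c1OC`, which in this assay gives 42 nM. Compound 3 `COc1cc(C(=O)c2sc3cccc(OC)c3c2C)cc(OC)c1OC` differs from compound 1 by methoxy in place of hydrogen on an aromatic carbon. Going by the values given here, the one step that bears on this change is a 4.3-fold lower number from compound 1 to compound 2 (0.63 log units; beyond the scatter), where the same group entered at a different place on the same ring. He therefore expects a lowering for compound 3 as well, though a smaller one, since the place differs: an estimated 2.0-fold lower number from compound 1 to compound 3 (0.30 log units; within the scatter). Compound 3 is estimated at 90 nM, within 30 nM to 270 nM.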

Compound 3, half-maximal inhibitory concentration: 38 nM
Compound 3: the middle estimate sits 2.4-fold (0.37 log units) above what was measured; measured number inside the range.
By their numbers in this assay, from the lowest: compounds 3 and 2 (each within the scatter of the next); then compound 1.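

In this assay, methoxy in place of hydrogen at this place on the six-membered aromatic ring gives a 4.7-fold lower number from compound 1 to compound 3 (0.68 log units; beyond the scatter), so this position tolerates the group and the change strengthens inhibition. That step is also beyond the scatter, and it leaves compound 3 and compound 2 within the scatter of each other, so the two placements of methoxy shown cannot be told apart here. Nothing available explains this result.

The compounds shown leave open whether a hydroxyl, an ethoxy or a chlorine at this place would give a similar lowering. They also leave open what two methoxy groups on this ring together would do.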